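Closing the diethylamino group into a ring

This account rests on a few compounds, and the source may have more. Where it says the series, first, only, none or still open, it means among the compounds named here.

In a functional assay on HCT-116 cells (Homo sapiens) for antiproliferative activity, read by MTT assay, with a stated time of 24 h (a higher number here means a weaker inhibitor, a lower number a stronger inhibitor), compound 1 `COc1ccc(C(=O)/C=C/c2ccc(N(C)C)cc2)c2c1C=CC(C)(C)O2` gives 1920 nM and compound 2 `CCN(CC)c1ccc(/C=C/C(=O)c2ccc(OC)c3c2OC(C)(C)C=C3)cc1` gives 620 nM, so compound 2 holds the lower, stronger number of the two. Compound 3 `COc1ccc(C(=O)/C=C/c2ccc(N3CCCC3)cc2)c2c1C=CC(C)(C)O2` keeps the shared core and changes one group: pyrrolidin-1-yl in place of diethylamino on an aromatic carbon. Here pyrrolidin-1-yl, with its five-membered non-aromatic ring, takes the place of diethylamino on an aromatic carbon. Among the compounds with values here, only one measured step bears on this change: a 3.1-fold lower number from compound 1 to compound 2 (0.49 log units; beyond the scatter). Within the data shown here, that modest step came from swapping dimethylamino for diethylamino at the same place, and no measured compound yet carries a ring there, so it is only a loose guide. The expected change is therefore small, with no step beyond the scatter, and the estimate is a 1.4-fold higher number from compound 2 to compound 3 (0.14 log units; within the scatter). For compound 3 the estimated value is 850 nM, within an expected range from 300 nM to 2200 nM.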

Compound 3, half-maximal inhibitory concentration: 8590 nM
Compound 3: middle estimate off by 10-fold (1.00 log units), on the low side; measured number outside the range, above it.
By their numbers in this assay, from the lowest: compound 2; then compound 1; then compound 3.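

In this assay, this position proves sensitive to the shape of the amine and not only to which atoms it holds: diethylamino and pyrrolidin-1-yl have the same heavy atoms, yet joining them into a ring gives a 14-fold higher number from compound 2 to compound 3 (1.14 log units; beyond the scatter). The ring also falls behind the smaller open-chain dimethylamino, with a 4.5-fold higher number from compound 1 to compound 3 (0.65 log units; beyond the scatter), so compound 3 is the weakest of the three, and the earlier gain from a larger open-chain amine does not carry over to this ring. Nothing shown here explains the loss.

Still open, as far as these compounds go, is whether the loss applies to rings at this position in general, as a six-membered piperidin-1-yl or morpholin-4-yl group would show. It is also unclear whether a longer open chain, such as dipropylamino, would extend the gain seen with diethylamino.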